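The source may report more compounds than this note shows. Statements on the series, on what has been measured and on what is new or still open speak of the compounds shown alone.

The measured compounds:

- compound 1 `COc1ccc(C2CC(c3ccc(NC(=O)c4cc(Cl)ccc4OC)cc3)=NN2C)cc1` — 88.1%
- compound 2 `COc1ccc(C2CC(c3ccc(NC(=O)c4cc(Cl)ccc4OC)cc3)=NN2c2ccccc2)cc1` — 94.8%
- compound 3 `COc1ccc(C2CC(c3ccc(NC(=O)c4cc(Cl)ccc4OC)cc3)=NN2)cc1` — 82.6%

All three share one core and were tested in a functional assay on the whole organism (strain albino) with Rattus norvegicus as the target, read by paw edema, with stated times of 1 h and 4 h, at a dose of 25 mg/kg by the oral route; on this read-out higher numbers stand for a stronger effect at the one dose given and lower numbers for a weaker effect. Compound 3 carries only a hydrogen on the ring nitrogen and gives the lowest of the three numbers: one step is a number 5.5 percentage points lower from compound 1 to compound 3 (within the scatter), while the other is a number 12.2 percentage points lower from compound 2 to compound 3 (beyond the scatter). So swapping that hydrogen for a methyl changes little, and swapping it for a phenyl brings a modest gain.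

Compound 4 `COc1ccc(C2CC(c3ccc(NC(=O)c4cc(Cl)ccc4OC)cc3)=NN2C(C)=O)cc1` is not yet measured. It differs from compound 3 in one place: acetyl in place of hydrogen on an amine nitrogen in a ring. Within the data shown here, no measured pair shows an acetyl at this nitrogen, so the two steps above are the only guide. Both point the same way or nowhere: a small group on that nitrogen left the number within the scatter, and a larger one raised it modestly. An acetyl is between the two in size, so the step is expected to be small and upward at most.

The estimate for compound 4 is therefore 87%, with a range from 76% to 96%. The expected step from compound 3 is a number 4.4 percentage points higher from compound 3 to compound 4 (within the scatter).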

Compound 4, a percentage reported as activity, at one dose (the size of the read-out at that dose, not a potency): 86%
Beside the measured number, compound 4's estimate is 1 percentage points above it; measured number inside the range.
By their numbers in this assay, from the lowest: compounds 3, 4, 1 and 2 (each within the scatter of the next, the first and the last beyond it).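

In this assay, the acetyl is the first group shown on this ring nitrogen that brings a carbonyl, and so a hydrogen-bond acceptor, yet the number does not move beyond the scatter from the compound with only a hydrogen there (a number 3.4 percentage points higher from compound 3 to compound 4 (within the scatter)) or from the one with a methyl (a number 2.1 percentage points lower from compound 1 to compound 4 (within the scatter)). Nor can the acetyl be told apart from the phenyl (a number 8.8 percentage points lower from compound 2 to compound 4 (within the scatter)), even though hydrogen and phenyl do differ (a number 12.2 percentage points lower from compound 2 to compound 3 (beyond the scatter)), so compound 4 sits within the scatter of both ends of this short series and adds no new level of effect at this position. Nothing measured here gives a reason for these numbers.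

The compounds shown leave open whether a benzoyl group, which would join the carbonyl of the acetyl to the ring of the phenyl, would go beyond the acetyl, and whether a longer chain ending in an amine or a carboxylic acid would be accepted on this nitrogen. With one dose in this read-out, they also leave open whether compounds that cannot be told apart here would stay so across other doses.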